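Propyl in place of isopropyl on the amine of compound 2

The source may report more compounds than this note shows. Statements on the series, on what has been measured and on what is new or still open speak of the compounds shown alone.

Measured in a physicochemical assay for acid dissociation, at 37 degrees C:
compound 1, `CCCN(CCC)Cc1cccnc1`: compound 1 gives 8.13
compound 2, `CC(C)NCc1cccnc1`: compound 2 gives 8.46
compound 3, `CCN(CC)Cc1cccnc1`: compound 3 gives 8.12

Compound 2 gives the highest of the three numbers; compound 1 and compound 3 each sit lower, and both gaps lie beyond the scatter. Within the data shown here, no two measured compounds differ in one place only, so no step is known. Compound 4, `CCCNCc1cccnc1`, has not yet been measured in this assay. It differs from compound 2 in one place: propyl in place of isopropyl on an amine nitrogen. Among the measured compounds shown here, none of the measured compounds shows what this change does on its own. In this assay the step is expected to be small, with no direction that can be called, most likely none beyond the scatter: the expected step is a number 0.01 log units lower from compound 2 to compound 4 (within the scatter). Compound 4 is estimated at 8.45, in the range 8.15 to 8.75.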

Compound 4, acid dissociation constant: 8.38
Beside the measured number, compound 4's estimate is 0.07 log units above it; the measured number falls inside the stated range.
By their numbers in this assay, from the lowest: compounds 3, 1, 4 and 2 (each within the scatter of the next, the first and the last beyond it).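

In this assay, propyl in place of isopropyl on an amine nitrogen gives a number 0.08 log units lower from compound 2 to compound 4 (within the scatter), so the two chains are not told apart at this position. Hydrogen in place of propyl on an amine nitrogen gives a number 0.25 log units higher from compound 1 to compound 4 (within the scatter), so this change also stays inside the scatter in the one pair available. No measured explanation bears on either step. Still open, as far as these compounds go, is whether a butyl chain or a cyclopropyl group on the amine nitrogen would also stay within the scatter of compound 4.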